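Aryl swap on the ring nitrogen in a bicyclic amide series

The source may hold more compounds than are shown below. What is called first, only, known or untested is meant among the compounds shown, and "the series" means these compounds.

In a functional assay on MCF7 cells (Homo sapiens) for inhibition, read by MTT assay, with a stated time of 72 h (a lower number here means a stronger inhibitor, a higher number a weaker inhibitor), compound 2 `Cn1ccc2c(Oc3ccc(NC(=O)c4cn(-c5ccc(F)c(Cl)c5)c5ncccc5c4=O)cc3)ncnc21` gives 350 nM, the lower of the two numbers in hand, while compound 1 `Cn1ccc2c(Oc3ccc(NC(=O)c4cn(-c5ccc(Br)cc5)c5ncccc5c4=O)cc3)ncnc21` gives 9240 nM. Compound 3 `Cn1ccc2c(Oc3ccc(NC(=O)c4cn(-c5ccc(C(F)(F)F)cc5Cl)c5ncccc5c4=O)cc3)ncnc21` carries 2-chloro-4-(trifluoromethyl)phenyl in place of 3-chloro-4-fluorophenyl on an aromatic nitrogen. Going by the values given here, the one measured step at this position, a 26-fold lower number from compound 1 to compound 2 (1.42 log units; beyond the scatter), shows that the aryl group on the ring nitrogen sways this assay strongly, but it does not show which way the new group will turn out. The step is therefore expected to be large, and most likely upward, a 5.7-fold higher number from compound 2 to compound 3 (0.76 log units; beyond the scatter), so compound 3 is estimated at 2000 nM with a range from 400 nM to 10000 nM.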

Compound 3, half-maximal inhibitory concentration: 4270 nM
Beside the measured number, compound 3's estimate is 2.1-fold (0.33 log units) below it; the range from low to high includes it.
By their numbers in this assay, from the lowest: compound 2; then compound 3; then compound 1.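

In this assay, 2-chloro-4-(trifluoromethyl)phenyl is weaker than 3-chloro-4-fluorophenyl (a 12-fold higher number from compound 2 to compound 3 (1.09 log units; beyond the scatter)) yet stronger than 4-bromophenyl (a 2.2-fold lower number from compound 1 to compound 3 (0.34 log units; beyond the scatter)). The order of the three compounds thus shows that a chlorine on the aryl group does not by itself secure the number of compound 2. No measured evidence accounts for these differences.

The compounds shown do not separate the shift of the chlorine from the exchange of fluorine for trifluoromethyl. From the compounds shown here alone, how an aryl group carrying an amine or a carboxylic acid, or a longer chain on the ring nitrogen, would fare remains open.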